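A few compounds are considered here, and "the series" means these few. Any claim that something is new, unique, unknown or untested is made for them only; others in the source may bear on it.

Of the compounds shown here, three built on one shared core have so far been measured in a functional assay on HL-60 cells (Homo sapiens) for antiproliferative activity, read by MTT assay, with a stated time of 48 h; a lower number here means a stronger inhibitor, a higher number a weaker inhibitor. Compound 1 `CSCC[C@H](NC(=O)c1cc2ccccc2cn1)C(=O)OCc1ccccc1` gives 44.9 nM. Compound 2 `NCCCC[C@H](NC(=O)c1cc2ccccc2cn1)C(=O)OCc1ccccc1` gives 68.2 nM, and compound 3 `CC(C)[C@H](NC(=O)c1cc2ccccc2cn1)C(=O)OCc1ccccc1` gives 78.9 nM. Among these numbers compound 1 has the lowest value, but its separation from the others is small: a 1.5-fold higher number from compound 1 to compound 2 (0.18 log units; within the scatter) and a 1.8-fold higher number from compound 1 to compound 3 (0.24 log units; within the scatter), while between the other two a 1.2-fold higher number from compound 2 to compound 3 (0.06 log units; within the scatter). All three measured values therefore sit within the usual scatter of one another.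

Compound 4 `O=C(C[C@H](NC(=O)c1cc2ccccc2cn1)C(=O)OCc1ccccc1)OCc1ccccc1` has not yet been measured. It differs from compound 1 in benzyloxycarbonyl in place of (methylsulfanyl)methyl on a saturated chain carbon, two bonds along the chain from an amide-type nitrogen and a carbonyl carbon. Within the data shown here, the steps that bear on this change are the two already seen from compound 1, a 1.5-fold higher number from compound 1 to compound 2 (0.18 log units; within the scatter) and a 1.8-fold higher number from compound 1 to compound 3 (0.24 log units; within the scatter), each of which exchanged the group on the saturated chain carbon bound to an amide-type nitrogen and a carbonyl carbon, and neither of which moved the number beyond the scatter. On that basis the change to compound 4 is expected to give no step beyond the scatter, a 1.2-fold higher number from compound 1 to compound 4 (0.09 log units; within the scatter). Compound 4 is accordingly estimated at 55 nM, with a range from 22 nM to 140 nM.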

Compound 4, half-maximal inhibitory concentration: 74 nM
Estimate against measurement, compound 4: 1.3-fold (0.13 log units) below; measured number inside the range.
By their numbers in this assay, from the lowest: compounds 1, 2, 4 and 3 (each within the scatter of the next).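

The benzyloxycarbonyl group is far larger than the (methylsulfanyl)methyl it replaces, with 10 heavy atoms against 3 and a six-membered aromatic ring where there was none, yet in this assay the exchange on this saturated chain carbon stays within the scatter (a 1.6-fold higher number from compound 1 to compound 4 (0.22 log units; within the scatter)). The same holds against the other two compounds (a 1.1-fold lower number from compound 3 to compound 4 (0.03 log units; within the scatter); a 1.1-fold higher number from compound 2 to compound 4 (0.04 log units; within the scatter)), so an aromatic ester at this position is indistinguishable in this assay from the open-chain groups of compound 1, compound 2 and compound 3, and all four compounds now lie within the scatter of one another. Nothing available explains why so large an exchange leaves the number within the scatter.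

The compounds shown leave open whether a free carboxylic acid in place of the benzyloxycarbonyl, or a hydroxymethyl or a plain methyl on the same carbon, would also stay within the scatter. They also leave open what the benzyl ester shared by all four compounds contributes, since a methyl ester or a free carboxylic acid at that end is not among them.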